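A few compounds are considered here, and "the series" means these few. Any claim that something is new, unique, unknown or untested is made for them only; others in the source may bear on it.

Measured so far:
compound 1 `Cc1cc(O)cc(-c2nn(CC#N)cc2-c2ccnc(-c3ccc(Oc4ccccc4)cc3)c2)c1` — > 100000 nM
compound 2 `COc1cc(C)cc(-c2nn(CC#N)cc2-c2ccnc(-c3ccc(N(C)C)cc3)c2)c1` — > 100000 nM

In a functional assay on K562 cells (Homo sapiens) for inhibition, read by sulforhodamine B assay, with a stated time of 48 h (a higher number here means that more compound is tolerated, a lower number that less compound is tolerated), compound 2 gives > 100000 nM, a limit of the assay and not a number. Compound 1 likewise sits at a limit; (the limit of > 100000 nM in this assay, at which 2 of the 2 values shown sit). Compound 3 `Cc1cc(O)cc(-c2nn(CC#N)cc2-c2ccnc(-c3ccc(N(C)C)cc3)c2)c1` is not yet measured. It differs from compound 2 by hydrogen in place of methyl on an oxygen on an aromatic ring. Going by the values given here, no measured step exists, so no size can be read off. Compound 1 already carries the hydroxy group and gives > 100000 nM, a limit. The expected step is a step that the limit leaves unreadable from compound 2 to compound 3, none beyond the scatter, with the assay most likely again returning a limit. Compound 3 is therefore expected at 150000 nM, within 50000 nM to 500000 nM.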

Compound 3, concentration lethal to 50% of the cells: > 100000 nM
Compound 3: only a limit was reported (the forecaster's own chance of this, stated with the estimate: 80%); the middle value is on the limit's open side.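

Compound 1, compound 2 and compound 3 all sit at a limit, so no step can be read from compound 2 to compound 3 or from compound 1 to compound 3: the limit of > 100000 nM in this assay, at which 3 of the 3 values shown sit.

The compounds shown leave open which structural change, if any, would bring a value within the measurable range.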